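The source may hold more compounds than are shown below. What is called first, only, known or untested is meant among the compounds shown, and "the series" means these compounds.

Compound 1 `Cc1ccccc1N(C)C(=O)c1ccc(-c2ccc(O)cc2)o1` gives 21 nM in an assay on T47D cells for inhibition of 17-beta-hydroxysteroid dehydrogenase type 1 (Homo sapiens), read by HPLC, with a stated time of 24 h; on this read-out higher numbers stand for weaker inhibition and lower numbers for stronger inhibition.
Compound 2 `Cc1cc(-c2ccc(C(=O)N(C)c3ccccc3C)o2)ccc1O` gives 8.6 nM in this assay.

For the measured compounds named here, compound 2 holds the lower of the two numbers in this assay; the single measured step, a 2.4-fold lower number from compound 1 to compound 2 (0.39 log units; beyond the scatter), is the gain from adding that methyl. Compound 3 `Cc1ccccc1N(C)C(=O)c1ccc(-c2ccc(O)c(F)c2)o1` carries fluoro in place of methyl on an aromatic carbon. Going by the values given here, no measured step covers a fluoro at this place; the methyl step bears on it only as the change now undone, so compound 3 is expected to land between compound 1 and compound 2, with a modest rise at most. The estimate for compound 3 is 14 nM (range 6 nM to 40 nM), an expected step of a 1.6-fold higher number from compound 2 to compound 3 (0.21 log units; within the scatter).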

Compound 3, half-maximal inhibitory concentration: 10 nM
Estimate against measurement, compound 3: 1.4-fold (0.15 log units) above; measured number inside the range.
By their numbers in this assay, from the lowest: compounds 2 and 3 (each within the scatter of the next); then compound 1.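

Placed ortho to a hydroxy group, fluoro in place of methyl gives a 1.2-fold higher number from compound 2 to compound 3 (0.07 log units; within the scatter) in this assay, so here the two groups cannot be told apart. Fluoro in place of hydrogen gives a 2.1-fold lower number from compound 1 to compound 3 (0.32 log units; beyond the scatter), which shows that the gain at this place is not confined to methyl, though only these two groups are shown. Nothing available here explains why the two groups match. The compounds shown leave open whether chloro, methoxy or an amine at this place would keep the number, and whether a second fluoro would add to it.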